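The compounds below may be only part of what the source reports. "The series", "measured", "known", "first", "only" and "open" are said of these compounds alone.

Compound 1 `Oc1ccc(CNc2cc(C(F)(F)F)cc3[nH]ncc23)cc1` is the weakest of the three measured compounds in an assay for inhibition of Indoleamine 2,3-dioxygenase 1 (Homo sapiens), with stated times of 10 min and 60 min (a lower number here means a stronger inhibitor, a higher number a weaker inhibitor), where compound 1 gives 36700 nM. Compound 2 `Oc1ccc(CNc2cc(C(F)(F)F)cc3[nH]ncc23)c(Cl)c1` gives 6020 nM in this assay, and compound 3 `O=[N+]([O-])c1ccc(CNc2cc(Br)cc3[nH]ncc23)cc1` gives 6970 nM. For the measured compounds named here, the one measured step, a 6.1-fold lower number from compound 1 to compound 2 (0.79 log units; beyond the scatter), concerns a chloro in place of hydrogen on an aromatic carbon of the pendant ring. Compound 4 `FC(F)(F)c1cc(NCC2CNC2)c2cn[nH]c2c1` differs from compound 1 by a different kind of change: azetidin-3-yl in place of 4-hydroxyphenyl on a saturated chain carbon bound to a nitrogen on an aromatic ring. Going by the values given here, no measured step exchanges the whole pendant ring for a small saturated ring, so the step from compound 1 to compound 2 and the values of compound 3 offer only indirect guidance. The pendant ring of compound 1 is replaced outright, and the change is therefore expected to shift this assay by an uncertain amount in either direction, with a modest loss judged somewhat more likely than a gain. Compound 4 is accordingly expected to give 50000 nM in this assay, within a range of 10000 nM to 200000 nM, which corresponds to an expected step of a 1.4-fold higher number from compound 1 to compound 4 (0.13 log units; within the scatter).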

Compound 4, half-maximal inhibitory concentration: > 100000 nM
Compound 4 gave a limit, no number (the forecaster's own chance of this, stated with the estimate: 35%); middle value at least 2.0-fold (0.30 log units) away from the limit.
By their numbers in this assay, from the lowest: compounds 2 and 3 (each within the scatter of the next); then compound 1. At a limit, above all of these: compound 4.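

Compound 4 gives only a limit and not a number in this assay, and that limit is the top of the values shown: the limit of > 100000 nM in this assay, at which 1 of the 4 values shown sits. For the compounds shown here, until now the only step at this position was a chloro added to the pendant ring, whereas azetidin-3-yl in place of 4-hydroxyphenyl gives an at least 2.7-fold higher number from compound 1 to compound 4 (0.43 log units; beyond the scatter), so the first outright exchange of that ring lost ground rather than gaining it. The two groups have the same counts of hydrogen-bond donors and acceptors and no net charge, so these counts do not separate them here.

The compounds shown leave open whether the loss follows from removing the aromatic ring or from the smaller ring size, which a piperidine or a pyridine in this place could separate. They also leave open how far compound 4 lies beyond its limit.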